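A few compounds are considered here, and "the series" means these few. Any claim that something is new, unique, unknown or untested is made for them only; others in the source may bear on it.

Measured compounds:
compound 1, `CCCn1ccnc1-c1cccc(Cl)c1CCc1cc(Br)ccc1OC`: 1900 nM
compound 2, `COc1ccc(Br)cc1CCc1ccccc1-c1ncc(C)n1C`: 51 nM

Of the compounds shown here, two have been tested in a functional assay on HEK293 cells (Homo sapiens), read by cAMP accumulation; on this read-out lower numbers stand for stronger inhibition and higher numbers for weaker inhibition. Compound 1 gives 1900 nM in this assay. Compound 2 gives 51 nM in this assay, the lower of the two numbers, and the gap between compound 2 and compound 1 lies well beyond the usual scatter of repeated measurements. For the measured compounds named here, compound 2 therefore stands as the stronger inhibitor of the pair on the numbers known so far.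

Compound 3, `CCc1cnc(-c2ccccc2CCc2cc(Br)ccc2OC)n1C`, is the next compound to be tested and differs from compound 2 in a single place: methyl in place of hydrogen on a saturated chain carbon bound to an aromatic carbon. Going by the values given here, no step between two measured compounds of this kind has been recorded, so there is no direct precedent for what it does. A change of one carbon at the edge of the molecule is small, and the step of a 1.0-fold lower number from compound 2 to compound 3 (0.01 log units; within the scatter) is expected to be slight, in either direction, and most likely to stay within the scatter. The estimated value for compound 3 in this assay is 50 nM, within a range from 20 nM to 150 nM.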

Compound 3, half-maximal inhibitory concentration: 170 nM
For compound 3 the middle estimate is 3.4-fold (0.53 log units) below the measured one; measured number outside the range, above it.
By their numbers in this assay, from the lowest: compound 2; then compound 3; then compound 1.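

Changing methyl to ethyl, which turns the 1,5-dimethyl-1H-imidazol-2-yl group into the 5-ethyl-1-methyl-1H-imidazol-2-yl group, gives in this assay a 3.3-fold higher number from compound 2 to compound 3 (0.52 log units; beyond the scatter), so a single added carbon on a saturated chain carbon bound to an aromatic carbon is enough to weaken inhibition measurably. For the compounds shown here, compounds 1 and 2 differ in more than one place, so their gap could not be tied to any one group, whereas this is the first step that isolates a single change and shows that this position is sensitive to what sits on it. Nothing measured here explains why the extra carbon weakens inhibition.

On these data alone, one step gives only a direction at one position, so it remains open whether inhibition would keep weakening with a longer chain such as propyl, or with a branched group such as isopropyl. Also open, as far as these compounds go, is whether a ring such as cyclopropyl, or a chain carrying oxygen such as methoxymethyl, would be tolerated here, and whether a lone hydrogen in place of the methyl would give a lower number than compound 2 does.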